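A few compounds are considered here, and "the series" means these few. Any claim that something is new, unique, unknown or untested is made for them only; others in the source may bear on it.

Compound 2, `O=C1/C(=C/c2ccccc2F)CN(C(=S)SCc2cn(Cc3ccc(F)cc3)nn2)C/C1=C\c1ccccc1F`, in a functional assay on DU-145 cells (Homo sapiens) for cytotoxicity, read by MTT assay, with a stated time of 24 h (a higher number here means a weaker inhibitor, a lower number a stronger inhibitor), gives 35700 nM. Compound 1, `O=C1/C(=C/c2ccccc2F)CN(C(=S)SCc2cn(Cc3ccccc3Cl)nn2)C/C1=C\c1ccccc1F`, carries 2-chlorophenyl in place of 4-fluorophenyl on a saturated chain carbon bound to an aromatic nitrogen; in this assay compound 1 gives 46300 nM, and the step is a 1.3-fold higher number from compound 2 to compound 1 (0.11 log units; within the scatter). Compound 3, `COc1ccc(/C=C2\CN(Cc3cn(Cc4ccc(F)cc4)nn3)C/C(=C\c3ccc(OC)cc3)C2=O)cc1`, is built on a different core; how the two cores differ is not broken down here. In this assay compound 3 gives 59400 nM, a number that sits together with those of compound 1 and compound 2. Compound 4, `COc1ccc(/C=C2\CN(Cc3cn(Cc4ccccc4Cl)nn3)C/C(=C\c3ccc(OC)cc3)C2=O)cc1`, has not yet been measured; it differs from compound 3 by 2-chlorophenyl in place of 4-fluorophenyl on a saturated chain carbon bound to an aromatic nitrogen, the same change at the same place as that between compound 2 and compound 1. The expectation for compound 4 rests on that earlier step, a 1.3-fold higher number from compound 2 to compound 1 (0.11 log units; within the scatter). The expected step is a 1.2-fold higher number from compound 3 to compound 4 (0.07 log units; within the scatter). For compound 4 the estimated value is 70000 nM, with a likely range from 35000 nM to 140000 nM.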

Compound 4, half-maximal inhibitory concentration: 17800 nM
Compound 4: middle estimate off by 3.9-fold (0.59 log units), on the high side; the measured number lies below the stated range.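

In this assay, replacing 4-fluorobenzyl with 2-chlorobenzyl gives a 3.3-fold lower number from compound 3 to compound 4 (0.52 log units; beyond the scatter), so the change does not carry over unaltered between these two cores: the same change on two cores in this assay, a 1.3-fold higher number (0.11 log units; within the scatter) from compound 2 to compound 1 and a 3.3-fold lower number (0.52 log units; beyond the scatter) from compound 3 to compound 4, 4.3-fold (0.64 log units) apart, beyond the scatter of two such steps. The result shows that, for this pair of cores, the outcome of the change depends on the core it is made on. Among the compounds shown here, it does not show which feature of the cores is responsible, and with only one pair on each core it gives no rule for any other core.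

The compounds shown leave open how an unsubstituted benzyl group would behave in place of either halogenated benzyl group on each core. They also leave open whether a longer chain carrying the same phenyl groups would show the same dependence on the core.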